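A few compounds are considered here, and "the series" means these few. Any claim that something is new, unique, unknown or untested is made for them only; others in the source may bear on it.

Measured compounds:
- compound 1, `COc1ccc(S(=O)(=O)N2CCc3cccc(-c4ccc([N+](=O)[O-])cc4)c32)cc1`: 51.3 nM
- compound 2, `COc1ccc(S(=O)(=O)N2CCc3cccc(-c4ccc(O)cc4)c32)cc1`: 123 nM
- compound 3, `COc1ccc(S(=O)(=O)N2CCc3cccc(-c4ccc(N(C)C)cc4)c32)cc1`: 553 nM

In a functional assay on KB-VIN10 cells (Homo sapiens) for inhibition, with a stated time of 72 h (on this read-out higher numbers stand for weaker inhibition and lower numbers for stronger inhibition), compound 3 gives the highest number of the three, so it is the weakest inhibitor here. The change to compound 4, `COc1ccc(S(=O)(=O)N2CCc3cccc(-c4ccccc4)c32)cc1`, is hydrogen in place of dimethylamino on an aromatic carbon. Among the measured compounds shown here, no measured step removes a group outright; the nearest guides are the swaps at the same carbon, a 4.5-fold higher number from compound 2 to compound 3 (0.65 log units; beyond the scatter) and an 11-fold higher number from compound 1 to compound 3 (1.03 log units; beyond the scatter), which show that this position shifts the read-out well beyond the scatter. Compound 4 is therefore expected to differ from compound 3, most likely toward a lower number, landing somewhere among the values of compounds 1 and 2. The estimated step is a 3.7-fold lower number from compound 3 to compound 4 (0.57 log units; beyond the scatter). For compound 4 the expected value is 150 nM, within 50 nM to 450 nM.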

Compound 4, half-maximal inhibitory concentration: 107 nM
Compound 4: the middle estimate sits 1.4-fold (0.15 log units) above what was measured, and the stated range covers the measured number.
By their numbers in this assay, from the lowest: compound 1; then compounds 4 and 2 (each within the scatter of the next); then compound 3.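

In this assay, the plain phenyl of compound 4 gives this position its unsubstituted reference, and dimethylamino is the group that stands out against it (a 5.2-fold lower number from compound 3 to compound 4 (0.71 log units; beyond the scatter)). Hydroxy is not separated from hydrogen (a 1.1-fold lower number from compound 2 to compound 4 (0.06 log units; within the scatter)), while nitro gives the stronger inhibition of that pair (a 2.1-fold higher number from compound 1 to compound 4 (0.32 log units; beyond the scatter)). Nothing available explains these differences. Still open, as far as these compounds go, is where other groups on this carbon would fall, such as a primary amine, a carboxylic acid or a longer alkyl chain.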